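A few compounds are considered here, and "the series" means these few. Any claim that something is new, unique, unknown or untested is made for them only; others in the source may bear on it.

Measured so far in a functional assay on CRL2813 cells (Homo sapiens) for cytotoxicity, read by sulforhodamine B assay, with a stated time of 5 days; on this read-out higher numbers stand for weaker inhibition and lower numbers for stronger inhibition:

- compound 1 `COC(=O)c1ccc(NC(=O)N[C@H]2CC[C@H](Oc3ccc(F)cc3)CC2)cc1` — 11600 nM
- compound 2 `O=C(Nc1cccc(C(F)(F)F)c1)N[C@H]1CC[C@@H](Oc2ccc(F)cc2)CC1` — 2600 nM
- compound 3 `O=C(Nc1cccc(C(F)(F)F)c1)N[C@H]1CC[C@H](Oc2ccccc2F)CC1` — 2450 nM

Compound 1 has the highest number of the three in this assay. Compounds 2 and 3 both give lower numbers than compound 1, and each of those gaps lies beyond the scatter; compounds 2 and 3 themselves lie within the scatter of each other, so nothing separates them. Among the compounds with values here, compounds 2 and 3 carry trifluoromethyl on the aryl urea and differ from compound 1 in more than one place, so no single step among the measured compounds is available to read off.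

Compound 4 `O=C(Nc1ccc(Cl)cc1)N[C@H]1CC[C@H](Oc2ccc(F)cc2)CC1` is not yet measured. It differs from compound 1 in one place: chloro in place of methoxycarbonyl on an aromatic carbon. Chloro in place of methoxycarbonyl on an aromatic carbon, para to a large group, has no measured counterpart here, so the size of the step is open. Since compounds 2 and 3, which also lack methoxycarbonyl, sit well below compound 1, compound 4 is expected to move toward a lower number, with the step of a 2.3-fold lower number from compound 1 to compound 4 (0.37 log units; beyond the scatter) estimated at around the edge of the scatter rather than clearly beyond it. Compound 4 is therefore expected at 5000 nM, with a range from 1500 nM to 15000 nM.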

Compound 4, half-maximal inhibitory concentration: > 20000 nM
Compound 4: only a limit was reported (the forecaster's own chance of this, stated with the estimate: 5%); middle value at least 4.0-fold (0.60 log units) from the limit.
By their numbers in this assay, from the lowest: compounds 3 and 2 (each within the scatter of the next); then compound 1. At a limit, above all of these: compound 4.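

Compound 4 gives > 20000 nM in this assay, and this value is a limit, not a number. Chloro in place of methoxycarbonyl on an aromatic carbon, para to a large group, is the only single-place step shown, an at least 1.7-fold higher number from compound 1 to compound 4 (0.23 log units; that floor lies within the scatter). Its floor does not separate the two compounds, so the step shows only that chloro at this position brings no lower number than methoxycarbonyl, and its true size cannot be read: the limit of > 20000 nM in this assay, at which 1 of the 4 values shown sits.

From the compounds shown here alone, whether another group at this position, such as a nitrile, an amine or a carboxylic acid, gives a lower number than methoxycarbonyl remains open. Within the data shown here, also open is what sets compounds 2 and 3 apart from compound 1 or compound 4, as no single-place step links them.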